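The source may report more compounds than this note shows. Statements on the series, on what has been measured and on what is new or still open speak of the compounds shown alone.

Compounds measured so far:

compound 1 `c1ccc2c(c1)CN[C@H](CN(CCCN1CCNCC1)[C@H]1CCCc3cccnc31)C2` 88%
compound 2 `CCN1CCN(CCCN(C[C@H]2Cc3ccccc3CN2)[C@H]2CCCc3cccnc32)CC1` 1%
compound 3 `c1ccc2c(c1)CN[C@@H](CN(CCCCN1CCNCC1)[C@H]1CCCc3cccnc31)C2` 15%

Compound 3 stands second of the three in an ADME assay on microsomes from liver (Rattus norvegicus) for metabolic stability, read by LC-MS, with a stated time of 10 min, tested at 0.5 uM; on this read-out lower numbers stand for a less stable compound and higher numbers for a more stable compound: its nearest neighbour is compound 2, whose number is lower than that of compound 3 by a margin beyond the scatter, while compound 1 lies far above it. Going by the values given here, the only step measured in one place is a number 14 percentage points higher from compound 2 to compound 3 (beyond the scatter), a modest rise beyond the scatter that combines shortening of the chain with loss of the ethyl group.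

Compound 4 `c1ccc2c(c1)CN[C@@H](CN(CCCN1CCNCC1)[C@H]1CCCc3cccnc31)C2` is the not yet measured neighbour of compound 3. It differs by piperazin-1-yl in place of (piperazin-1-yl)methyl on a saturated chain carbon, three bonds along the chain from an amine nitrogen. This is a chain shortening of the same kind as part of the step from compound 2 to compound 3, now taken from 4-(piperazin-1-yl)butyl to 3-(piperazin-1-yl)propyl. Among the compounds with values here, compound 1 carries that shorter propyl chain on the other configuration of the shared core and gives 88%, but no single-place step connects it to compound 4, so its value is only a hint of what the shorter chain can reach. Within the data shown here, on the strength of the one measured step, a modest rise is expected, so compound 4 is estimated at 35% in this assay, within 10% to 75%, a step of a number 20 percentage points higher from compound 3 to compound 4 (beyond the scatter).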

Compound 4, percent of the compound remaining: 100%
For compound 4 the middle estimate is 65 percentage points below the measured one; measured number outside the range, above it.
By their numbers in this assay, from the lowest: compound 2; then compound 3; then compound 1; then compound 4.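

In this assay, going by these compounds alone, shortening 4-(piperazin-1-yl)butyl to 3-(piperazin-1-yl)propyl, with nothing else altered, gives a number 85 percentage points higher from compound 3 to compound 4 (beyond the scatter), so chain length at this place has a far larger effect on the percent remaining than the one earlier step suggested. Replacing ethyl with hydrogen on the ring amine nitrogen, with the propyl chain kept, gives a number 99 percentage points higher from compound 2 to compound 4 (beyond the scatter), which shows that the modest rise seen earlier combined two large changes running in opposite directions, a rise on losing the ethyl group and a fall on lengthening the chain. Configuration at the saturated ring carbon has a much smaller effect in this pair, with a number 12 percentage points higher from compound 1 to compound 4 (beyond the scatter), and this step reads configuration alone: the fact that compounds 1 and 4 differ only in the configuration as drawn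

The compounds shown leave open whether a 2-(piperazin-1-yl)ethyl chain would hold the percent remaining as the propyl chain does, and whether a methyl group on the ring amine nitrogen would cost as much as ethyl does. They also do not show whether the ethyl group and the butyl chain would have the same effects on the other configuration of the shared core.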